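The source may report more compounds than this note shows. Statements on the series, on what has been measured and on what is new or still open speak of the compounds shown alone.

Measured compounds:
compound 1 `CCc1cccc(NC(=O)c2cccc(/C=C3\CC(=O)N(Cc4ccccc4)C3=O)c2)c1` with 91500 nM
compound 2 `CCCCCN1C(=O)C/C(=C\c2cccc(C(=O)Nc3cccc(CC)c3)c2)C1=O` with 83300 nM

In an ADME assay on SW480 cells (Homo sapiens) for cytotoxicity, read by MTT assay, with a stated time of 72 h (on this read-out higher numbers stand for weaker inhibition and lower numbers for stronger inhibition), compound 1 gives 91500 nM, the highest of the two numbers in this set. Its nearest neighbour is compound 2, and the step of a 1.1-fold lower number from compound 1 to compound 2 (0.04 log units; within the scatter) lies within the scatter, so the two compounds cannot be ordered on these numbers. That step changes only the group on a saturated chain carbon bound to an amide-type nitrogen in a ring, and leaves the rest of the shared core untouched.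

Compound 3 `CCOc1ccc(NC(=O)c2cccc(/C=C3\CC(=O)N(Cc4ccccc4)C3=O)c2)cc1` is not yet measured. It differs from compound 1 in one place: 4-ethoxyphenyl in place of 3-ethylphenyl on an amide-type nitrogen. Among the compounds with values here, no measured step touches this part of the molecule, so the only step available, from compound 1 to compound 2, does not bear on it; it merely shows that one change elsewhere on the core moved the number by less than the scatter. With nothing pointing in either direction, the step of a 1.0-fold lower number from compound 1 to compound 3 (0.01 log units; within the scatter) is expected to stay within the scatter. The estimate for compound 3 is 90000 nM, with a range from 40000 nM to 200000 nM.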

Compound 3, half-maximal inhibitory concentration: 73200 nM
Estimate against measurement, compound 3: 1.2-fold (0.09 log units) above; measured number inside the range.
By their numbers in this assay, from the lowest: compounds 3, 2 and 1 (each within the scatter of the next).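

In this assay, within the data shown here, this is the first reading at the aryl group on the amide-type nitrogen, and it gives a 1.3-fold lower number from compound 1 to compound 3 (0.10 log units; within the scatter) with 4-ethoxyphenyl in place of 3-ethylphenyl. The earlier pair spoke only to the group on the saturated chain carbon bound to the amide-type nitrogen in a ring, whereas this pair shows that the group on the other amide-type nitrogen can also be exchanged, with an oxygen and a hydrogen-bond acceptor entering, without the number leaving the scatter. No measurement offered here accounts for this result or says what the entering oxygen contributes in these cells.

The exchange alters both the name and the place of the substituent on the aromatic ring, so these compounds cannot separate the ethyl-to-ethoxy change from the shift from 3-substitution to 4-substitution. They also leave open whether any group on this nitrogen would carry the number beyond the scatter, such as a 4-aminophenyl or a 4-carboxyphenyl group, and whether 4-ethoxyphenyl would behave alike with the chain of compound 2.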